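A few compounds are considered here, and "the series" means these few. Any claim that something is new, unique, unknown or untested is made for them only; others in the source may bear on it.

In a physicochemical assay for lipophilicity (on this read-out higher numbers stand for higher lipophilicity and lower numbers for lower lipophilicity), compound 2, with the structure `CCC1C(=O)N(C)c2cnc(-n3ccnc3-c3ccc(F)cc3)nc2N1C1CCC(F)(F)C1`, gives 3.1, the highest of the three numbers here. Compound 1, with the structure `CC[C@@H]1C(=O)N(C)c2cnc(-n3ccnc3-c3ccccc3)nc2N1[C@H]1CCOC1`, gives 1.9 in this assay, and compound 3, with the structure `CC[C@@H]1C(=O)N(C)c2cnc(-n3ccnc3-c3ccccc3)nc2N1[C@@H]1CCOC1`, gives 1.8. For the measured compounds named here, the only step measured between two compounds that differ in one place runs a number 0.10 log units lower from compound 1 to compound 3 (within the scatter), and it lies within the scatter because of the fact that compounds 1 and 3 differ only in the configuration as drawn. Compound 4, with the structure `CCC1C(=O)N(C)c2cnc(-n3ccnc3-c3ccc(F)cc3)nc2N1c1ccc(C#N)cc1`, has not yet been measured in this assay. It differs from compound 2 as follows: 4-cyanophenyl in place of 3,3-difluorocyclopentyl on a nitrogen on an aromatic ring in a ring. Going by the values given here, the one measured step concerns a change of configuration alone and does not bear on a swap of one group for another, so nothing measured here speaks directly to this step. The expectation is therefore a modest downward step, a number 0.40 log units lower from compound 2 to compound 4 (beyond the scatter), estimated rather than derived from a matched pair. Compound 4 is thus expected to give about 2.7 in this assay, with a range from 2.1 to 3.3.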

Compound 4, partition coefficient: 2.7
Beside the measured number, compound 4's estimate shows no gap at the digits printed; the measured number falls inside the stated range.
By their numbers in this assay, from the lowest: compounds 3 and 1 (each within the scatter of the next); then compound 4; then compound 2.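

Putting 4-cyanophenyl in place of 3,3-difluorocyclopentyl on this nitrogen, next to the ring atom that bears an ethyl group, gives a number 0.40 log units lower from compound 2 to compound 4 (beyond the scatter) in this assay, and this is the only step shown here that exchanges one group for another at this position. It shows that a five-membered non-aromatic ring of carbon can be replaced by a six-membered aromatic ring carrying a nitrile with only a modest change in this number. Nothing shown here explains the size of this step. The pair also cannot separate the part played by the aromatic ring from that of the nitrile, so a plain phenyl group on this nitrogen remains an open case. Going by these compounds, a carboxylic acid or an amine in place of the nitrile on that ring also remains open.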